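Camphor hydrazones and Vero cell toxicity: a trifluoroacetyl variant

The compounds below may be only part of what the source reports. "The series", "measured", "known", "first", "only" and "open" are said of these compounds alone.

Measured so far:
compound 1, `CC1(C)[C@@H]2CC[C@@]1(C)/C(=N/NC(=O)c1cccs1)C2`, 363000 nM in an ADME assay on Vero cells (Chlorocebus sabaeus) for cytotoxicity, read by spectrophotometry, with a stated time of 4 days; on this read-out higher numbers stand for lower toxicity in this test and lower numbers for higher toxicity in this test
compound 2, `CC12C=CC3(O1)C(C(=O)N1CCSC13)C2C(=O)N/N=C1\C[C@H]2CC[C@]1(C)C2(C)C`, > 250000 nM

Going by the values given here, compound 1 carries a thiophene amide hydrazone on the bicyclic core; in this assay compound 1 gives 363000 nM, the only numerical value shown in this test. For compound 2, a more elaborate fused tricyclic attached to the same hydrazone, the result is a limit of the assay: compound 2 gives > 250000 nM, which means only that its toxicity lies beyond what the test could resolve. With one number and (the limit of > 250000 nM in this assay, at which 1 of the 2 values shown sits), nothing can be said about a measured step between the two.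

Compound 3, `CC1(C)[C@@H]2CC[C@@]1(C)/C(=N/NC(=O)C(F)(F)F)C2`, has not yet been measured. It differs from compound 1 by trifluoromethyl in place of thiophen-2-yl on a carbonyl carbon. Among the compounds with values here, since no measured step is available here, the direction is open, and the step from compound 1 to compound 3 is expected to stay within the scatter, as a 1.2-fold lower number from compound 1 to compound 3 (0.08 log units; within the scatter). Compound 3 is therefore estimated at 300000 nM, with a plausible range from 100000 nM to 600000 nM, and a real chance that the assay returns only a limit.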

Compound 3, half-maximal cytotoxic concentration: > 250000 nM
Compound 3 gave a limit, no number; the forecaster's own chance of this, stated with the estimate: 40%; the middle value does not contradict the limit.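

In this assay compound 3 gives > 250000 nM, which is a limit of the assay and not a number. No step from compound 1 to compound 3 can be read, because the comparison ends at such a limit: the limit of > 250000 nM in this assay, at which 2 of the 3 values shown sit.

The compounds shown leave open whether trifluoromethyl in place of thiophen-2-yl on a carbonyl carbon shifts this read-out at all, and in which direction.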